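Dithiocarbamate variation at the thiocarbonyl amine

The compounds below may be only part of what the source reports. "The series", "measured", "known", "first", "only" and "open" are said of these compounds alone.

Measured compounds:
compound 1 `Nc1ccccc1NC(=O)c1ccc(CSC(=S)N2CCN(c3ccc(Cl)cc3)CC2)cc1`: 29%
compound 2 `CC1CCN(C(=S)SCc2ccc(C(=O)Nc3ccccc3N)cc2)CC1`: 87.4%
compound 3 `Nc1ccccc1NC(=O)c1ccc(CSC(=S)N(Cc2ccccc2)Cc2ccccc2)cc1`: 32.5%

Three compounds share a core and differ only in the amine attached to the thiocarbonyl carbon. In a functional assay on A-375 cells (Homo sapiens) for antiproliferative activity, read by CCK-8 assay, with a stated time of 72 h, tested at 8 uM (on this read-out lower numbers stand for a weaker effect and higher numbers for a stronger effect at the one concentration tested), compound 2 gives 87.4%, the highest of the three numbers. Its nearest neighbour is compound 3, which gives 32.5% in this assay, a gap beyond the scatter. Compound 1, the furthest, gives 29% in this assay, also beyond the scatter. Compound 2 thus stands clearly apart from the two compounds that carry a second aromatic ring in the amine part.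

Compound 4 `Nc1ccccc1NC(=O)c1ccc(CSC(=S)N2CCCC2)cc1` has not yet been measured. It differs from compound 2 in one place: pyrrolidin-1-yl in place of 4-methylpiperidin-1-yl on a thiocarbonyl carbon. Going by the values given here, no step between measured compounds of this kind is available, so the expectation rests on the values of compound 2 and on the weaker values of compound 1 and compound 3. Because compound 2 reaches 87.4% with a small saturated amine, compound 4 is expected to stay nearer to it than to the other two, with a modest downward step estimated as a number 15.4 percentage points lower from compound 2 to compound 4 (beyond the scatter). The estimate for compound 4 in this assay is 72%, within a range from 45% to 92%.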

Compound 4, a percentage reported as inhibition, at one concentration (the size of the read-out at that concentration, not a potency): 89.5%
Beside the measured number, compound 4's estimate is 17.5 percentage points below it; the range from low to high includes it.
By their numbers in this assay, from the lowest: compounds 1 and 3 (each within the scatter of the next); then compounds 2 and 4 (each within the scatter of the next).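

In this assay, replacing 4-methylpiperidin-1-yl with pyrrolidin-1-yl on a thiocarbonyl carbon gives a number 2.1 percentage points higher from compound 2 to compound 4 (within the scatter), so this read-out does not separate the two amines. Going by these compounds alone, this is the first single-change comparison at this position, and it shows that the high reading of compound 2 is not confined to one saturated ring: a five-membered ring without a methyl group gives a reading within the scatter of it. No measured information offers a reason for this result.

The change alters ring size and removes the methyl group together, so piperidin-1-yl would be needed to separate the two. On these data alone, it also remains open whether the same level holds for morpholin-4-yl, with an oxygen in the ring, or for an open-chain amine such as diethylamino.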